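The source may report more compounds than this note shows. Statements on the series, on what has been measured and on what is new or still open speak of the compounds shown alone.

In a functional assay on HCT-15 cells (Homo sapiens) (a lower number here means that less compound is needed, a higher number that more compound is needed for the effect), two compounds have been measured:

- compound 1 `COc1cc(C2OC(c3cccc(N(C)C)c3)=NN2C(C)=O)cc(OC)c1OC` gives 0.16 uM in this test
- compound 2 `COc1cc(C2OC(c3ccc(N(C)C)cc3)=NN2C=O)cc(OC)c1OC` gives 0.096 uM in this test

These two numbers lie within the usual scatter of each other, so compound 2 cannot be separated from compound 1 on the data so far. Both compounds share the same core.

Compound 3 `COc1cc(C2OC(c3ccc(N(C)C)cc3)=NN2C(=O)CN)cc(OC)c1OC` has not yet been measured. It is built from compound 2 with a single structural change, aminomethyl in place of hydrogen on a carbonyl carbon in which aminomethyl takes the place of hydrogen on a carbonyl carbon whose other neighbour is an amide-type nitrogen in a ring. The same difference can be read as formyl to (aminomethyl)carbonyl.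

Going by the values given here, no two measured compounds differ in just one place, so nothing here shows directly what such a change does. The expectation therefore starts from compound 2 at 0.096 uM and stays cautious. What is expected in this assay is a 1.6-fold higher number from compound 2 to compound 3 (0.19 log units; within the scatter) and so no change beyond the scatter, with a slight lean toward a higher number. Compound 3 is estimated at 0.15 uM with an expected range from 0.03 uM to 0.8 uM in a real measurement.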

Compound 3, concentration for half-maximal effect: 0.65 uM
Estimate against measurement, compound 3: 4.3-fold (0.64 log units) below; the range from low to high includes it.
By their numbers in this assay, from the lowest: compounds 2 and 1 (each within the scatter of the next); then compound 3.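

Going by these compounds alone, putting aminomethyl in place of hydrogen on the carbonyl carbon gives a 6.8-fold higher number from compound 2 to compound 3 (0.83 log units; beyond the scatter) in this assay and is the first change in one place whose size can be read. It shows that this carbonyl carbon, whose other neighbour is an amide-type nitrogen in a ring, is sensitive to what it carries: with the rest of the molecule unchanged, going from formyl to (aminomethyl)carbonyl is enough to move the number beyond the scatter, toward more compound being needed. Nothing available explains this rise, so it stands as an observation only.

A single step cannot show whether the result depends on the amine itself or on having any group larger than hydrogen at this place. A hydroxymethyl group, with oxygen in place of the amine nitrogen, or a longer aminoethyl chain on the same carbonyl carbon of compound 2 would help separate those two readings.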